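This account rests on a few compounds, and the source may have more. Where it says the series, first, only, none or still open, it means among the compounds named here.

Compound 1 `COc1ccc(-c2cnc(NC(=O)c3ccccc3O)n2C)cc1` gives > 100000 nM in a toxicity assay on THP-1 cells (Homo sapiens) for inhibition (on this read-out lower numbers stand for higher toxicity in this test and higher numbers for lower toxicity in this test), a limit.
Compound 2 `CCC(=O)Nc1ncc(-c2ccc(OC)cc2)n1C` gives > 100000 nM in this assay, a limit.
Compound 3 `COc1ccc(-c2cnc(NC(=O)c3ccccc3F)n2C)cc1` gives > 100000 nM in this assay, a limit.

All three values sit at the limit of this assay, as the limit of > 100000 nM in this assay, at which 3 of the 3 values shown sit, records, so compound 3 stands level with the other two and no number is known for any of them. Compound 4 `COc1ccc(-c2cnc(NC(=O)c3ccccc3Br)n2C)cc1` differs from compound 3 by bromo in place of fluoro on an aromatic carbon. The steps reaching compound 3, a step that the two limits leave unreadable from compound 1 to compound 3 and a step that the two limits leave unreadable from compound 2 to compound 3, are both unreadable; each ends at a limit. No size or direction can therefore be read for the step to compound 4. The expectation is that compound 4 also stays at the limit, a step that the limit leaves unreadable from compound 3 to compound 4. Compound 4 is thus estimated at 150000 nM, with a range from 40000 nM to 600000 nM.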

Compound 4, half-maximal cytotoxic concentration: > 100000 nM
Compound 4 was reported as a limit; the forecaster's own chance of this, stated with the estimate: 85%; the middle value lies beyond the limit too.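

Within the data shown here, no step between compound 1, compound 2, compound 3 and compound 4 can be read, because each value is a limit and not a number: the limit of > 100000 nM in this assay, at which 4 of the 4 values shown sit.
The compounds shown leave open how large any of these changes is in this assay and at what concentration any of the four would show toxicity.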